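The compounds below may be only part of what the source reports. "The series", "measured", "known", "first", "only" and "open" are said of these compounds alone.

Working notes on the series, in a functional assay on the whole organism (Tail, strain ICR) with Mus musculus as the target, in the tail flick test, with a stated time of 30 min, at a dose of 25 umol/kg by the oral route; on this read-out higher numbers stand for a stronger effect at the one dose given and lower numbers for a weaker effect.

Compound 1 `C[C@H](NC(=O)CN(c1ncnc2c1ncn2C1CCCCO1)C1CC1)C(=O)OCc1ccccc1` gives 55.9%. Among the compounds with values here, compound 3 `CC(C)(C)OC(=O)NCCCC[C@H](NC(=O)CN(c1ncnc2c1ncn2C1CCCCO1)C1CC1)C(=O)OCc1ccccc1` gives 18.3%; the step of a number 37.6 percentage points lower from compound 1 to compound 3 (beyond the scatter) is the one measured change here. Compound 2 `O=C(O)C[C@H](NC(=O)CN(c1nc(Cl)nc2[nH]cnc12)C1CC1)C(=O)O` gives 19.9%, within the scatter of compound 3 and well under compound 1.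

Compound 4 `CC[C@H](C)[C@H](NC(=O)CN(c1nc(Cl)nc2[nH]cnc12)C1CC1)C(=O)O` differs from compound 2 by sec-butyl in place of carboxymethyl on a saturated chain carbon bound to an amide-type nitrogen and a carbonyl carbon. Within the data shown here, no measured pair covers this change: the single step, from compound 1 to compound 3, adds a chain on a different core, so it gives no guide to the direction here. The expectation for compound 4 therefore rests on compound 2 alone, and the step of a number 4.1 percentage points higher from compound 2 to compound 4 (within the scatter) is expected to stay within the scatter. Compound 4 is estimated at 24%, in a range of 5% to 48%.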

Compound 4, a percentage reported as activity, at one dose (the size of the read-out at that dose, not a potency): 30.3%
The estimate for compound 4 lay 6.3 percentage points below the measured number, within the range that was stated.
By their numbers in this assay, from the lowest: compounds 3 and 2 (each within the scatter of the next); then compound 4; then compound 1.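

On the chlorinated core, at a saturated chain carbon bound to an amide-type nitrogen and a carbonyl carbon, replacing carboxymethyl with sec-butyl gives a number 10.4 percentage points higher from compound 2 to compound 4 (beyond the scatter) in this assay. This modest step shows that the number responds to this side chain on this core, and that an all-carbon group of the same heavy-atom count gives the higher number here. Nothing on hand accounts for the step.

Going by these compounds, whether an amine or a longer carbon chain at this place would give a different number stays open. On these data alone, whether the same change carries over to the core of compound 1 also stays open.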